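Moving the Fluorine on the Benzyl Group

The source may report more compounds than this note shows. Statements on the series, on what has been measured and on what is new or still open speak of the compounds shown alone.

In an ADME assay on C8166 cells (Homo sapiens) for cytotoxicity, read by MTT assay (a lower number here means that less compound is tolerated, a higher number that more compound is tolerated), compound 1 (`O=C(O)c1cn(-c2ccc(Br)cc2)c2ccc(Cc3cccc(Cl)c3F)c(O)c2c1=O`) gives 85000 nM. Compound 2 (`O=C(O)c1cn(Cc2cccc(F)c2)c2ccc(Cc3cccc(Cl)c3F)c(O)c2c1=O`) gives 69000 nM, which places the two within the scatter of each other. Compound 3 (`O=C(O)c1cn(Cc2ccc(F)cc2)c2ccc(Cc3cccc(Cl)c3F)c(O)c2c1=O`) carries 4-fluorophenyl in place of 3-fluorophenyl on a saturated chain carbon bound to an aromatic nitrogen. Among the compounds with values here, only one measured step bears on this change, a 1.2-fold lower number from compound 1 to compound 2 (0.09 log units; within the scatter), a replacement on the aromatic nitrogen. A change beyond the scatter is therefore not expected, and the estimated step is a 1.0-fold higher number from compound 2 to compound 3 (0.02 log units; within the scatter). Compound 3 is expected at 72000 nM, with an estimated range of 35000 nM to 140000 nM.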

Compound 3, half-maximal cytotoxic concentration: 65800 nM
Beside the measured number, compound 3's estimate is 1.1-fold (0.04 log units) above it, within the range that was stated.
By their numbers in this assay, from the lowest: compounds 3, 2 and 1 (each within the scatter of the next).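

In this assay, within the data shown here, moving the fluorine on the benzyl group gives a 1.0-fold lower number from compound 2 to compound 3 (0.02 log units; within the scatter), so this position now has a change of fluorine placement alone on record, where the earlier compounds offered only a replacement of the whole group. The replacement of 4-bromophenyl by 4-fluorobenzyl on the aromatic nitrogen gives a 1.3-fold lower number from compound 1 to compound 3 (0.11 log units; within the scatter), which also stays within the scatter. No evidence is available that bears on this result.

The compounds shown leave open how this assay responds to an amine on the benzyl group, or to a longer chain in its place on the aromatic nitrogen.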